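This account rests on a few compounds, and the source may have more. Where it says the series, first, only, none or still open, it means among the compounds named here.

Series notes. Compound 1 `CN(C)CCCNC(=O)c1cc(NC(=O)c2cc(NC(=O)c3cc(NC(=N)N)cn3C)cn2C)cn1C` has no result in an ADME assay on HEK293 cells (Homo sapiens) for cytotoxicity, read by fluorescence and resazurin assay, with a stated time of 20 h; on this read-out higher numbers stand for lower toxicity in this test and lower numbers for higher toxicity in this test; its entry reads "not determined" (no result reported). For the measured compounds named here, compound 2 `CC(C)CCc1sc(NC(=O)c2cc(NC(=O)c3cc(NC(=N)c4ccc(F)cc4)cn3C)cn2C)nc1C(=O)NCCCN(C)C` is the only member with a number: in this assay compound 2 gives 18 ug/mL, so it stands alone on the scale, and compound 1 offers nothing to set beside it. Compound 3 `CC(C)CCc1sc(NC(=O)c2cc(NC(=O)c3cc(NC(=N)c4ccc(Cl)cc4)cn3C)cn2C)nc1C(=O)NCCCN(C)C` is the next member and is not yet measured. Relative to compound 2 the change is chloro in place of fluoro on an aromatic carbon. Going by the values given here, no step between two measured compounds is available to calibrate this exchange, so the expectation rests on compound 2 alone and on the single-atom scope of the change. The step expected from compound 2 to compound 3 in this assay is a 1.2-fold lower number from compound 2 to compound 3 (0.08 log units; within the scatter), which is meant to stay within the usual scatter, in no particular direction. On that basis compound 3 is estimated at 15 ug/mL in this assay, with a range from 7 ug/mL to 35 ug/mL.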

Compound 3, half-maximal cytotoxic concentration: 10 ug/mL
Compound 3: middle estimate off by 1.5-fold (0.18 log units), on the high side; the measured number falls inside the stated range.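

In this assay, the exchange of 4-fluorophenyl to 4-chlorophenyl now has a measured size at this position, para to a large group: a 1.8-fold lower number from compound 2 to compound 3 (0.26 log units; within the scatter). This places compound 2 and compound 3 within the usual scatter of each other, so this one-atom exchange gives no separable difference on this read-out and assigns no direction to it. Nothing available bears on the reason for this result.

Any step involving compound 1 cannot be read, as its entry holds no number. Also open is how the read-out responds when an amine, a carboxylic acid or a methoxy group occupies this position, since fluoro and chloro are the only groups shown there.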